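The source may hold more compounds than are shown below. What is called first, only, known or untested is meant among the compounds shown, and "the series" means these compounds.

Compound 1 `c1ccc(C2CC3(N4CCCC4)CC(NCCN4CCCC4)C2C(c2ccccc2)C3)cc1` and compound 3 `c1ccc(C2CC3(N4CCCC4)CCN(CCCN4CCCCC4)C2C(c2ccccc2)C3)cc1` rest on closely related cores; the difference between the two cores is not broken down here. In an ADME assay on L6 cells (Rattus norvegicus) for cytotoxicity (a lower number here means a stronger inhibitor, a higher number a weaker inhibitor), compound 1 gives 28400 nM. In this assay compound 3 gives 28700 nM, and the two numbers lie within the scatter of each other. Compound 2 `CN(C)C12CCN(CCCN3CCCCC3)C(C(c3ccccc3)C1)C(c1ccccc1)C2` differs from compound 3 by dimethylamino in place of pyrrolidin-1-yl on a saturated ring carbon; in this assay compound 2 gives 58400 nM, which is a 2.0-fold higher number from compound 3 to compound 2 (0.31 log units; beyond the scatter). Compound 4 `CN(C)C12CC(NCCN3CCCC3)C(C(c3ccccc3)C1)C(c1ccccc1)C2` carries the same kind of change relative to compound 1, namely (dimethylamino in place of pyrrolidin-1-yl on a saturated ring carbon). The surroundings of the place differ: in compound 3 two ring bonds run from two ring atoms that each bear a phenyl group, whereas in compound 1 two ring bonds run from the ring atom that bears a (2-(pyrrolidin-1-yl)ethyl)amino group and two from the ring atom that bears a phenyl group. Among the compounds with values here, the expected step in this assay is a 2.0-fold higher number from compound 1 to compound 4 (0.30 log units; within the scatter), because the only precedent for this change is a 2.0-fold higher number from compound 3 to compound 2 (0.31 log units; beyond the scatter). Compound 4 is therefore estimated at 57000 nM, with an expected range from 30000 nM to 110000 nM.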

Compound 4, half-maximal inhibitory concentration: 22800 nM
Estimate against measurement, compound 4: 2.5-fold (0.40 log units) above; measured number below the stated range.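

In this assay, dimethylamino in place of pyrrolidin-1-yl on a saturated ring carbon gives a 1.2-fold lower number from compound 1 to compound 4 (0.10 log units; within the scatter), so no change can be read on the core of compound 1. Set beside the step on the other core, this step cannot be told apart from it: the same change on two cores in this assay, a 2.0-fold higher number (0.31 log units; beyond the scatter) from compound 3 to compound 2 and a 1.2-fold lower number (0.10 log units; within the scatter) from compound 1 to compound 4, 2.5-fold (0.40 log units) apart, within the scatter of two such steps This gives no ground for saying that the change behaves differently on the two cores, but it does not show that the change carries over unaltered either, as it rests on only two pairs in one assay and says nothing about the cause of either step.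

The compounds shown leave open how other groups on the same saturated ring carbon, such as diethylamino or morpholin-4-yl, would read in this assay. They also leave open whether the swap would give a similar step on a core carrying a longer chain in place of the (2-(pyrrolidin-1-yl)ethyl)amino group.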